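Fluorine added to the cyclized analogue

The source may report more compounds than this note shows. Statements on the series, on what has been measured and on what is new or still open speak of the compounds shown alone.

Of the compounds shown here, two sharing the same core have been measured in a functional assay on A549 cells (Homo sapiens) for inhibition, read by sulforhodamine B assay, with a stated time of 48 h; on this read-out lower numbers stand for stronger inhibition of growth and higher numbers for weaker inhibition of growth. Compound 1 `COC(=O)[C@@]1(C)CCC=C2[C@@H]1CC[C@@H](C)[C@]2(C)Cc1c[nH]c2ccc(F)cc12` carries an open indole ring bearing a fluorine, and in this assay compound 1 gives 6200 nM. Compound 2 `COC(=O)[C@@]1(C)CC[C@@H]2C3=C1CC[C@@H](C)[C@]3(C)C[C@@H]1c3ccccc3N[C@H]21` has the indole closed into an additional ring and carries no fluorine; in this assay compound 2 gives 39000 nM, the highest of the two numbers and therefore the weaker growth inhibitor, a gap that lies beyond the usual scatter. The two compounds differ in more than one place, so their values show only what each one does on its own.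

Compound 3 `COC(=O)[C@@]1(C)CC[C@@H]2C3=C1CC[C@@H](C)[C@]3(C)C[C@@H]1c3cc(F)ccc3N[C@H]21` keeps the closed ring system of compound 2 and adds a single change: fluoro in place of hydrogen on an aromatic carbon. Among the compounds with values here, no measured pair shows what this change alone does on this core, so the direction is uncertain. Compound 3 is expected to give 25000 nM, within a range from 8000 nM to 80000 nM. This corresponds to an expected step of a 1.6-fold lower number from compound 2 to compound 3 (0.19 log units; within the scatter), small and possibly within the scatter.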

Compound 3, concentration for 50% growth inhibition: 25000 nM
Compound 3: middle estimate and measured number agree at the digits printed; the measured number falls inside the stated range.
By their numbers in this assay, from the lowest: compound 1; then compounds 3 and 2 (each within the scatter of the next).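

In this assay, the exchange of hydrogen for fluoro on this aromatic carbon, meta to a fused ring and para to a fused ring, comes with a 1.6-fold lower number from compound 2 to compound 3 (0.19 log units; within the scatter) and so gives no reading that separates the two compounds. Within the data shown here, this is the first view of this single change on the core shared by compound 2 and compound 3, something the earlier pair could not offer, as its members differ in more than one place: here, one added fluorine atom at this position leaves growth inhibition indistinguishable from that of the compound with hydrogen. No supporting measurement is available to explain this outcome.

From the compounds shown here alone, whether a different group on the same aromatic carbon, such as chlorine, a methoxy group or an amine, would produce a step beyond the scatter remains open. What fluoro does on the core of compound 1 also remains open, and the compounds shown hold no single-change pair on that core to answer it.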